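This account rests on a few compounds, and the source may have more. Where it says the series, first, only, none or still open, it means among the compounds named here.

Measured so far:
- compound 1, `COc1cc(-c2cc(/C=C/C(=O)c3ccc(N)cc3)[nH]n2)cc(OC)c1OC`: -59%
- compound 2, `COc1ccc(-c2cc(/C=C/C(=O)c3ccc(OC)c(OC)c3)[nH]n2)cc1`: -63%
- compound 3, `COc1ccc(-c2cc(/C=C/C(=O)c3ccc(N)cc3)[nH]n2)cc1`: -70%

In a functional assay on NCI-H460 cells (Homo sapiens) for cytotoxicity, read by sulforhodamine B assay, with a stated time of 48 h, tested at 100 uM (a lower number here means a stronger effect, a higher number a weaker effect of the compound at the concentration tested), compound 1 gives -59%, the highest of the three numbers. Compound 2 gives -63%, which lies within the scatter of compound 1. Compound 3 gives -70%, and that number sits beyond the scatter below compound 1. Compounds 2 and 3 carry the same group on the shared core apart from the ring on the carbonyl carbon, and their two values lie within the scatter of one another.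

The next compound, compound 4, `COc1ccc(C(=O)/C=C/c2cc(-c3cc(OC)c(OC)c(OC)c3)n[nH]2)cc1OC`, is compound 1 with one exchange: 3,4-dimethoxyphenyl in place of 4-aminophenyl on a carbonyl carbon. Compound 4 is not yet measured in this assay.

Within the data shown here, no step between measured compounds is available for this exchange. Since the values of compounds 2 and 3 lie close together, the step of a number 5 percentage points higher from compound 1 to compound 4 (within the scatter) is expected to be small, upward if anything, and not beyond the scatter. Compound 4 is therefore estimated to give -54%, with a likely range from -74% to -34%.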

Compound 4, a percentage reported as activity, at one concentration (the size of the read-out at that concentration, not a potency): -65%
Beside the measured number, compound 4's estimate is 11 percentage points above it; the measured number falls inside the stated range.
By their numbers in this assay, from the lowest: compounds 3, 4, 2 and 1 (each within the scatter of the next, the first and the last beyond it).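

In this assay, putting 3,4-dimethoxyphenyl in place of 4-aminophenyl on a carbonyl carbon gives a number 6 percentage points lower from compound 1 to compound 4 (within the scatter). Among these compounds, this is the first direct one-place comparison at this position, and it shows that, on the core of compound 1, the effect at the tested concentration holds when the entering group has more heavy atoms and no hydrogen-bond donor. No measurement is available that explains this outcome.

The compounds shown leave open whether other groups at this position, such as an unsubstituted phenyl, a 4-hydroxyphenyl or a phenyl carrying a carboxylic acid, would give a step beyond the scatter. Going by these compounds, the read-out is taken at one concentration, so any difference in potency between compound 1 and compound 4 also remains open.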